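The compounds below may be only part of what the source reports. "The series", "measured", "known", "first", "only" and "open" are said of these compounds alone.

Measured compounds:
- compound 1 `COc1ccc(Nc2nccc(-c3sc(SC)nc3C)n2)c(OC)c1`, in a functional assay on MV4-11 cells (Homo sapiens) for inhibition, read by resazurin assay, with a stated time of 72 h (on this read-out lower numbers stand for stronger inhibition of growth and higher numbers for weaker inhibition of growth), compound 1 gives 530 nM
- compound 2 `COc1ccc(Nc2nccc(-c3cn(C(C)C)c4ccccc34)n2)c(OC)c1`, in this assay compound 2 gives 3250 nM

For the measured compounds named here, compound 1 has the lowest number of the two measured; compound 2 lies beyond the scatter above it, and no single-point step links the two, so only the two values as they stand can be compared.

Compound 3 `COc1ccc(Nc2nccc(-c3sc(N(C)C)nc3C)n2)c(OC)c1` has not been measured. It differs from compound 1 by dimethylamino in place of methylsulfanyl on an aromatic carbon, on the five-membered aromatic ring of the shared core. Going by the values given here, no measured pair in this set carries a comparable change, so there is no reference step from which to read the direction; the exchange of one small group for another of similar count gives no ground to expect a move beyond the scatter in either direction in this assay. The working expectation is therefore a value near that of compound 1, with the range widened to allow for a modest shift either way.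

For compound 3 the estimated step of a 1.3-fold higher number from compound 1 to compound 3 (0.12 log units; within the scatter) is expected to stay within the scatter. Compound 3 is estimated at 700 nM, with a range from 250 nM to 2000 nM.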

Compound 3, concentration for 50% growth inhibition: 170 nM
Compound 3: the middle estimate sits 4.1-fold (0.61 log units) above what was measured; the measured number lies below the stated range.
By their numbers in this assay, from the lowest: compound 3; then compound 1; then compound 2.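

Working notes on the series: the aromatic carbon next to the ring nitrogen and next to the ring sulfur is not a silent point in this assay, since dimethylamino in place of methylsulfanyl gives a 3.1-fold lower number from compound 1 to compound 3 (0.49 log units; beyond the scatter). For the compounds shown here, this is the only single-point step in the set, and it lies beyond the scatter even though the two groups carry the same counts of hydrogen-bond donors and acceptors, and neither has a ring or a net charge. What separates them in the printed counts is the exchange of sulfur for nitrogen and the heavy-atom count, and no measurement on either group bears on why the number moved.

One step at one position leaves the shape of the trend here open: whether a smaller amine such as methylamino, a longer chain such as diethylamino, or a ring amine such as morpholine or pyrrolidine would continue, hold or reverse the move is not settled by these compounds. As far as these compounds go, it is equally open whether the step carries over to other parts of the shared core, as the methyl group and the dimethoxyphenyl amine stay fixed in both compounds.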